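Fluoro to chloro: a small swap, a cautious estimate

This account rests on a few compounds, and the source may have more. Where it says the series, first, only, none or still open, it means among the compounds named here.

Of the compounds shown here, two sharing one core have so far been tested in a functional assay on MIA PaCa-2 cells (Homo sapiens) for inhibition, read by MTT assay, with a stated time of 48 h; a higher number here means a weaker inhibitor of growth, a lower number a stronger inhibitor of growth. Compound 1 (`CN1CC[C@H](c2c(O)cc(O)c3c(=O)cc(/C=C/c4c(F)c(F)c(F)c(F)c4F)oc23)[C@H](O)C1`), which carries a 2,3,4,5,6-pentafluorophenyl group, gives 1000 nM. Compound 2 (`CN1CC[C@H](c2c(O)cc(O)c3c(=O)cc(/C=C/c4ccccc4F)oc23)[C@H](O)C1`), which carries a 2-fluorophenyl group, gives 3000 nM, the higher of the two numbers and so the weaker growth inhibition.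

Compound 3 (`CN1CC[C@H](c2c(O)cc(O)c3c(=O)cc(/C=C/c4ccccc4Cl)oc23)[C@H](O)C1`) has not been measured yet. It has chloro in place of fluoro, a change counted as chloro in place of fluoro on an aromatic carbon, on an aromatic carbon of a six-membered aromatic ring of carbon only, ortho to a large group. Within the data shown here, the only measured step, a 3.0-fold higher number from compound 1 to compound 2 (0.48 log units; beyond the scatter), is modest but beyond the scatter. Among the measured compounds shown here, it bears on this swap only loosely, since it changes how many fluoro groups the ring carries and no chloro compound has been measured. A step of that size is therefore a rough upper guide, and a smaller one is expected here. The estimated change is a 1.5-fold lower number from compound 2 to compound 3 (0.18 log units; within the scatter), which would not clearly stand out from the scatter. Compound 3 is estimated at 2000 nM, with an expected range from 700 nM to 5000 nM.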

Compound 3, concentration for 50% growth inhibition: 8000 nM
The estimate for compound 3 lay 4.0-fold (0.60 log units) below the measured number; the measured number lies above the stated range.
By their numbers in this assay, from the lowest: compound 1; then compound 2; then compound 3.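

The swap at this place, on an aromatic carbon ortho to a large group, is not neutral in this assay: chloro in place of fluoro gives a 2.7-fold higher number from compound 2 to compound 3 (0.43 log units; beyond the scatter) and so weakens growth inhibition, showing that the identity of this one halogen atom matters, which the earlier step, a change in the number of fluoro groups, could not show. Set against the fully fluorinated ring, the 2-chlorophenyl group gives an 8.0-fold higher number from compound 1 to compound 3 (0.90 log units; beyond the scatter), which makes compound 3 the weakest of the three and widens the span of numbers that changes on this ring alone can produce. No measurement in hand offers a reason for the loss seen with chloro.

The compounds shown leave open where bromo, methyl or methoxy at this same place would fall relative to compound 2, and so whether fluoro is a favourable group here or chloro is simply an unfavourable one. They also leave open whether a ring carrying several chloro groups would regain strength in the way the pentafluorophenyl ring of compound 1 stands ahead of the 2-fluorophenyl ring of compound 2.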